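The source may hold more compounds than are shown below. What is called first, only, known or untested is meant among the compounds shown, and "the series" means these compounds.

Measured so far in an assay (Canis lupus familiaris) for binding affinity to platelet-activating factor receptor (Homo sapiens), read by radioligand binding; on this read-out higher numbers stand for weaker inhibition and lower numbers for stronger inhibition:
compound 1 `COc1cccc(-c2ccc(C(=O)N[C@H](C)CCCc3cccnc3)cc2)c1`, 20 nM
compound 2 `O=C(NCCCCc1cccnc1)c1ccc(-c2ccccc2)c(-c2ccccc2)c1`, 5 nM
compound 3 `COc1cccc(-c2ccc(C(=O)NCCCCc3cccnc3)cc2)c1`, 280 nM

Compound 3 carries the highest number of the three. Going by the values given here, the only single-change step that reaches it is a 14-fold higher number from compound 1 to compound 3 (1.15 log units; beyond the scatter). Compound 2, with 5 nM, sits far lower still, but its difference from compound 3 is not a single change and is left uninterpreted. Compound 4 `Cc1cccc(-c2ccc(C(=O)NCCCCc3cccnc3)cc2)c1` differs from compound 3 by methyl in place of methoxy on an aromatic carbon. Among the compounds with values here, no measured step touches the substituent on this ring; the one measured step concerns the saturated chain carbon bound to the amide-type nitrogen and says nothing about the aryl substituent. Without such a precedent the expected step is a 1.3-fold lower number from compound 3 to compound 4 (0.10 log units; within the scatter), small and within the scatter. Compound 4 is therefore estimated at 220 nM, range 70 nM to 700 nM.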

Compound 4, half-maximal inhibitory concentration: 500 nM
Beside the measured number, compound 4's estimate is 2.3-fold (0.36 log units) below it; the range from low to high includes it.
By their numbers in this assay, from the lowest: compound 2; then compound 1; then compounds 3 and 4 (each within the scatter of the next).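

Going by these compounds alone, on the aromatic carbon carrying the 3-methoxyphenyl substituent, the change to 3-methylphenyl gives a 1.8-fold higher number from compound 3 to compound 4 (0.25 log units; within the scatter) in this assay, the first measured step at this place. Removing the oxygen and the one hydrogen-bond acceptor counted for methoxy therefore leaves the two compounds within the scatter of each other. No supporting data bear on this result.

From the compounds shown here alone, whether a hydroxyl, a chlorine or an amine on this carbon would give a step beyond the scatter remains open. Also open, going by these compounds, is whether the chain methyl present in compound 1 would have a comparable effect alongside 3-methylphenyl.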